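A few compounds are considered here, and "the series" means these few. Any claim that something is new, unique, unknown or untested is made for them only; others in the source may bear on it.

Working notes on the quinolone-carboxamide series.

Three members of the series have been measured in an assay on isolated protein for inhibition of tyrosine-protein kinase receptor UFO (Homo sapiens), read by FRET and Z'-LYTE, with a stated time of 1.5 h; a higher number here means a weaker inhibitor, a lower number a stronger inhibitor. Compound 1 `Cc1c(C(=O)Nc2ccc(Oc3ncnc4[nH]cc(-c5ccccc5)c34)c(F)c2)c(=O)c2c(Cl)cccc2n1C` gives only a limit of the assay, > 10000 nM, and no number; this is the limit at which one of the three values sits (the limit of > 10000 nM in this assay, at which 1 of the 3 values shown sits). Compound 2 `Cc1c(C(=O)Nc2ccc(Oc3ncnc4[nH]cc(-c5ccccc5)c34)c(F)c2)c(=O)c2cc(Br)ccc2n1C` gives 3120 nM in this assay. Compound 3 `CCc1ccc2c(c1)c(=O)c(C(=O)Nc1ccc(Oc3cccc4occ(-c5ccccc5)c34)c(F)c1)c(C)n2C`, which carries a different core and an ethyl group on its fused ring system, gives 192 nM in this assay. Of the two numbers in hand, compound 2 therefore stands at the higher one, and the gap between compound 2 and compound 3 lies beyond the usual scatter of repeated measurements.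

The next member, compound 4 `COc1ccc2c(c1)c(=O)c(C(=O)Nc1ccc(Oc3ncnc4[nH]cc(-c5ccccc5)c34)c(F)c1)c(C)n2C`, has not yet been measured in this assay. It differs from compound 2 in one place: methoxy in place of bromo on an aromatic carbon. Going by the values given here, no measured pair isolates this change, so its size in this assay is not known from the data. On the basis of compound 2 at 3120 nM alone, a moderate step toward a lower number is expected from compound 2 to compound 4, of about a 2.1-fold lower number from compound 2 to compound 4 (0.32 log units; beyond the scatter), though a step within the scatter would not be surprising. Compound 4 is accordingly expected to give about 1500 nM in this assay, with a likely range from 400 nM to 6000 nM.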

Compound 4, half-maximal inhibitory concentration: 99 nM
The estimate for compound 4 lay 15-fold (1.18 log units) above the measured number; measured number below the stated range.
By their numbers in this assay, from the lowest: compounds 4 and 3 (each within the scatter of the next); then compound 2. At a limit, above all of these: compound 1.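

In this assay, going by these compounds alone, this position on an aromatic carbon of the shared core responds strongly to the group it carries: methoxy in place of bromo gives a 32-fold lower number from compound 2 to compound 4 (1.50 log units; beyond the scatter) and is the first measured change that stands alone in one place. The earlier compounds shown here offered no pair of this kind, so the size of a change at this position could not be read from them, whereas the series now has one large, directly measured step here. Methoxy brings a hydrogen-bond acceptor that bromo does not have, but no measurement in hand bears on the cause of the step.

The compounds shown leave open whether the step depends on the oxygen or on the whole methoxy group, which hydroxy, ethoxy or a dimethylamino group at the same position would help to separate. They also leave open whether methoxy in place of bromo gives a step of similar size on a different core, since this single pair is the only measured case.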